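The source may hold more compounds than are shown below. What is called first, only, known or untested is meant among the compounds shown, and "the series" means these compounds.

Three compounds share the core of compound 1 `O=C(CCl)Nc1ccc(S(=O)(=O)Oc2ccccc2I)cc1`; compound 2 `O=C(CCCCl)Nc1ccc(S(=O)(=O)Oc2ccccc2I)cc1` and compound 3 `CCCNC(=O)Nc1ccc(S(=O)(=O)Oc2ccccc2I)cc1` vary only the group on the carbonyl carbon. In a functional assay on M21 cells (Homo sapiens) for antiproliferative activity, read by sulforhodamine B assay, with a stated time of 48 h (on this read-out lower numbers stand for stronger inhibition and higher numbers for weaker inhibition), compound 1 gives 3900 nM, compound 2 gives 7200 nM and compound 3 gives 5400 nM, the second highest of the three numbers, all within the scatter of one another. Compound 4 `CCCCCNC(=O)Nc1ccc(S(=O)(=O)Oc2ccccc2I)cc1` differs from compound 3 by ethyl in place of hydrogen on a saturated chain carbon, three bonds along the chain from an amide-type nitrogen. Among the compounds with values here, no measured step lengthens the chain in this position; the nearest comparison is the chain extension a 1.8-fold higher number from compound 1 to compound 2 (0.27 log units; within the scatter), and the swaps a 1.4-fold higher number from compound 1 to compound 3 (0.14 log units; within the scatter) and a 1.3-fold lower number from compound 2 to compound 3 (0.12 log units; within the scatter) likewise stayed within the scatter. For compound 4 the expected step in this assay is a 1.0-fold higher number from compound 3 to compound 4 (0.01 log units; within the scatter), nothing beyond the scatter. Compound 4 is estimated at 5500 nM, within a range of 2500 nM to 12000 nM.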

Compound 4, half-maximal inhibitory concentration: 5900 nM
Compound 4: the middle estimate sits 1.1-fold (0.03 log units) below what was measured, and the stated range covers the measured number.
By their numbers in this assay, from the lowest: compounds 1, 3, 4 and 2 (each within the scatter of the next).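

Ethyl in place of hydrogen on this saturated chain carbon, three bonds along the chain from an amide-type nitrogen, gives in this assay a 1.1-fold higher number from compound 3 to compound 4 (0.04 log units; within the scatter), so the first lengthening measured at this position leaves the number within the scatter. Pentylamino also stays within the scatter of the two chloroalkyl groups on the carbonyl carbon, with a 1.2-fold lower number from compound 2 to compound 4 (0.09 log units; within the scatter) and a 1.5-fold higher number from compound 1 to compound 4 (0.18 log units; within the scatter). No measurement at hand bears on the reason for this result.

From the compounds shown here alone, whether a longer chain such as octyl, or a chain ending in an amine or a carboxylic acid, would move the number beyond the scatter stays open. Going by these compounds, a phenyl ring in place of the pentyl chain is equally open.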